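The compounds below may be only part of what the source reports. "The series", "measured", "known", "first", "only" and "open" are said of these compounds alone.

Measured so far in a functional assay on MDA-MB-231 cells (Homo sapiens) for cytotoxicity, read by MTT assay, with a stated time of 72 h (on this read-out lower numbers stand for stronger inhibition and higher numbers for weaker inhibition), for three compounds:
- compound 1 `O=C1c2c[n+]([O-])c3ccccc3c2C(=O)c2c1c1ccccc1n2Cc1cn([C@H]2O[C@H](CO)[C@@H](O)[C@H]2O)nn1` gives 1700 nM 
- compound 2 `O=C1c2c[n+]([O-])c3ccccc3c2C(=O)c2c1c1ccccc1n2Cc1cn(C[C@H](O)CO)nn1` gives 1310 nM 
- compound 3 `CC1(C)O[C@@H](CO)[C@H](Cn2cc(Cn3c4c(c5ccccc53)C(=O)c3c[n+]([O-])c5ccccc5c3C4=O)nn2)O1` gives 680 nM 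

Compound 3 stands level with compound 2 (a 1.9-fold lower number from compound 2 to compound 3 (0.28 log units; within the scatter)) and lower than compound 1 (a 2.5-fold lower number from compound 1 to compound 3 (0.40 log units; beyond the scatter)). Compound 4 `CC1(C)OC[C@H](Cn2cc(Cn3c4c(c5ccccc53)C(=O)c3c[n+]([O-])c5ccccc5c3C4=O)nn2)O1` departs from compound 3 by hydrogen in place of hydroxymethyl on a saturated ring carbon. Within the data shown here, no measured step makes this exact change. The side-chain swaps that bear on it are small: (a 1.3-fold lower number from compound 1 to compound 2 (0.11 log units; within the scatter)) and (a 1.9-fold lower number from compound 2 to compound 3 (0.28 log units; within the scatter)), with only the modest step above beyond the scatter. In this assay, from the compounds shown here alone, no step beyond the scatter is therefore expected, and the direction stays open. The expected step is (a 1.0-fold lower number from compound 3 to compound 4 (0.02 log units; within the scatter)) for this change. For compound 4 the estimated value is 650 nM with an expected range of 300 nM to 1400 nM in this series.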

Compound 4, half-maximal inhibitory concentration: 530 nM
Beside the measured number, compound 4's estimate is 1.2-fold (0.09 log units) above it, and the stated range covers the measured number.
By their numbers in this assay, from the lowest: compounds 4, 3, 2 and 1 (each within the scatter of the next, the first and the last beyond it).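

In this assay, the hydroxymethyl on this saturated ring carbon is not needed to hold the number, since hydrogen in its place stays within the scatter (a 1.3-fold lower number from compound 3 to compound 4 (0.11 log units; within the scatter)). With hydrogen there, the 2,2-dimethyl-1,3-dioxolan-4-yl group separates beyond the scatter from the 1,2-dihydroxyethyl group (a 2.5-fold lower number from compound 2 to compound 4 (0.39 log units; beyond the scatter)), which compound 3 did not do, and the gap to the 3,4-dihydroxy-5-(hydroxymethyl)oxolan-2-yl compound also widens (a 3.2-fold lower number from compound 1 to compound 4 (0.51 log units; beyond the scatter)). Nothing available explains these steps. Open, from the compounds shown here alone, is how an amine, a carboxylic acid or a longer chain on this ring carbon would read.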